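The compounds below may be only part of what the source reports. "The series", "measured", "known", "first", "only" and "open" are said of these compounds alone.

Measured so far: compound 1 `N#CNC(=N)NCCCCCn1nc(-c2ccccc2)ccc1=O`, compound 2 `CN(C)/C(=N/CCCCn1nc(-c2ccccc2)ccc1=O)NC#N`, compound 3 `C/N=C(/NC#N)NCCCCCCn1nc(-c2ccccc2)ccc1=O`.

In a functional assay on the whole organism (stomach) with Rattus norvegicus as the target (on this read-out lower numbers stand for an effect already at smaller amounts and higher numbers for an effect only at larger amounts of compound), compound 1 reaches only the limit of the assay, > 100 mg/kg. In this assay compound 2 gives 30.3 mg/kg. Compound 3 likewise shows only the limit of the assay, > 100 mg/kg; two of the three values sit at that limit (the limit of > 100 mg/kg in this assay, at which 2 of the 3 values shown sit), so compound 3 stands at the weak end of what the numbers can tell.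

Compound 4 `C/N=C(/NC#N)NCCCCCn1nc(-c2ccccc2)ccc1=O` differs from compound 3 by a group of 7 heavy atoms (3 carbon, 4 nitrogen; no ring) in place of a group of 8 heavy atoms (4 carbon, 4 nitrogen; no ring), on a saturated chain carbon, five bonds along the chain from an aromatic nitrogen. The step of an at least 3.3-fold lower number from compound 1 to compound 2 (0.51 log units; beyond the scatter) also shortens the chain and alters the cyanoguanidine end, and moves from a limit to a number. The step that the two limits leave unreadable from compound 1 to compound 3 runs between two limits. Within the data shown here, no step between compound 1 and compound 4 or between compound 2 and compound 4 is measured; their values are simply a limit and a number beside the estimate below.

Compound 4 is therefore expected to sit near the limit or modestly within it, an estimated step of an at least 1.2-fold lower number from compound 3 to compound 4 (0.09 log units; that floor lies within the scatter). The estimate for compound 4 in this assay is 80 mg/kg, with a range from 30 mg/kg to 200 mg/kg.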

Compound 4, dose for half-maximal effect: 100 mg/kg
Compound 4: the middle estimate sits 1.3-fold (0.10 log units) below what was measured; the measured number falls inside the stated range.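

Compound 4 gives the series a readable step on a saturated chain carbon, four bonds along the chain from an aromatic nitrogen, and this one runs to a higher number in this assay: a 3.3-fold higher number from compound 2 to compound 4 (0.52 log units; beyond the scatter). Exchanging one group of 8 heavy atoms (4 carbon, 4 nitrogen; no ring) for another is thus enough to move the number beyond the scatter, so heavy-atom count alone does not set the value here. The other two new steps cannot be read: a number no higher from compound 3 to compound 4 (the limit leaves the size open) and a number no higher from compound 1 to compound 4 (the limit leaves the size open). Each of them starts from a limit: the limit of > 100 mg/kg in this assay, at which 2 of the 4 values shown sit.

Compound 2 and compound 4 differ in both chain length and the substitution on the cyanoguanidine end, and the values do not separate these two changes. As far as these compounds go, how a butyl chain with a methyl cyanoguanidine, or an amine or a carboxylic acid at the chain end, would read in this assay remains open.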